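A few compounds are considered here, and "the series" means these few. Any claim that something is new, unique, unknown or untested is made for them only; others in the source may bear on it.

Compound 1 `Cc1ccc(S(=O)(=O)Cc2ccccc2)cc1C#Cc1cc(Cl)ccc1OCC(=O)O` is the weaker of the two measured compounds in an assay on CHO cells for displacement of a labelled ligand from prostaglandin D2 receptor 2 (Homo sapiens), read by scintillation counting (a higher number here means a weaker inhibitor, a lower number a stronger inhibitor), where it gives 5 nM; compound 2 `CS(=O)(=O)c1ccc(F)c(C#Cc2cc(Cl)ccc2OCC(=O)O)c1`, with 3.3 nM, sits within the scatter of that figure, so neither can be called stronger. Compound 3 `Cc1ccc(S(=O)(=O)N2CCCCC2C)cc1C#Cc1cc(Cl)ccc1OCC(=O)O` differs from compound 1 by 2-methylpiperidin-1-yl in place of benzyl on a sulfonyl sulfur. Among the compounds with values here, no measured pair shows this change, so the expectation rests on compound 1 alone. The step from compound 1 is estimated as a 1.6-fold higher number from compound 1 to compound 3 (0.20 log units; within the scatter), a small loss that may not exceed the scatter. Compound 3 is therefore expected to give 8 nM, between 2 nM and 30 nM.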

Compound 3, inhibition constant: 1.9 nM
Compound 3: middle estimate off by 4.2-fold (0.62 log units), on the high side, and the stated range ends above it.
By their numbers in this assay, from the lowest: compounds 3, 2 and 1 (each within the scatter of the next, the first and the last beyond it).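

In this assay the swap of benzyl for 2-methylpiperidin-1-yl on a sulfonyl sulfur gives a 2.6-fold lower number from compound 1 to compound 3 (0.42 log units; beyond the scatter) and so a modest gain, showing that this place accepts a non-aromatic ring holding a nitrogen. An aromatic ring of carbon only is thus not required here in this pair, and both groups count 7 heavy atoms. No measurement at hand explains the gain. As far as these compounds go, whether the methyl group matters stays open, as does whether plain piperidin-1-yl or morpholin-4-yl would give a similar number at this place.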